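Swapping the Aryl Group on a Piperazine Ring

The source may report more compounds than this note shows. Statements on the series, on what has been measured and on what is new or still open speak of the compounds shown alone.

Measured compounds:
- compound 1, `O=C([C@@H]1C[C@H](N2CCN(c3ccc(Br)cc3)CC2)CN1)N1CCSC1`, gives 9 nM
- compound 2, `N#Cc1ccnc(N2CCN([C@@H]3CN[C@H](C(=O)N4CCSC4)C3)CC2)c1`, gives 1.9 nM
- compound 3, `O=C([C@@H]1C[C@H](N2CCN(c3ccccc3Cl)CC2)CN1)N1CCSC1`, gives 10.9 nM

All three share one core and were tested in an assay on a cell-free system (plasma) for inhibition of Dipeptidyl peptidase 4 (Rattus norvegicus), read by fluorescence; on this read-out lower numbers stand for stronger inhibition and higher numbers for weaker inhibition. Compound 3 stands highest of the three numbers; its gap to compound 1 is within the scatter (a 1.2-fold higher number from compound 1 to compound 3 (0.08 log units; within the scatter)), while compound 2 lies well below it (a 5.7-fold higher number from compound 2 to compound 3 (0.76 log units; beyond the scatter)). Compound 4, `O=C([C@@H]1C[C@H](N2CCN(c3ccncc3)CC2)CN1)N1CCSC1`, differs from compound 3 by pyridin-4-yl in place of 2-chlorophenyl on an amine nitrogen in a ring. Among the measured compounds shown here, two steps bear on this: a 4.7-fold lower number from compound 1 to compound 2 (0.68 log units; beyond the scatter), where a nitrogen-containing ring bearing a nitrile replaced a halogen-bearing ring, and a 5.7-fold higher number from compound 2 to compound 3 (0.76 log units; beyond the scatter), the reverse. Compound 4 brings a ring nitrogen but neither nitrile nor halogen, so the expected step is a 1.1-fold higher number from compound 3 to compound 4 (0.04 log units; within the scatter), likely within the scatter. Compound 4 is expected at 12 nM, with a range of 3 nM to 50 nM.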

Compound 4, half-maximal inhibitory concentration: 3.9 nM
Beside the measured number, compound 4's estimate is 3.1-fold (0.49 log units) above it; measured number inside the range.
By their numbers in this assay, from the lowest: compound 2; then compound 4; then compounds 1 and 3 (each within the scatter of the next).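

A carbon-only ring is not needed at this amine nitrogen: pyridin-4-yl, with neither nitrile nor halogen, beats both halogen-bearing rings, with a 2.8-fold lower number from compound 3 to compound 4 (0.45 log units; beyond the scatter) and a 2.3-fold lower number from compound 1 to compound 4 (0.36 log units; beyond the scatter). Much of the gain seen with 4-cyanopyridin-2-yl is therefore reached without the nitrile, though a gap remains, with a 2.1-fold higher number from compound 2 to compound 4 (0.31 log units; beyond the scatter). No evidence on why these numbers move is available here.

As far as these compounds go, whether the ring nitrogen or the loss of halogen drives the gain stays open. So does the outcome with unsubstituted phenyl or with a methoxy group on the pyridine ring.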